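This account rests on a few compounds, and the source may have more. Where it says the series, first, only, none or still open, it means among the compounds named here.

Among the three compounds measured so far in an ADME assay on microsomes from liver (Rattus norvegicus) for metabolic stability, with a stated time of 60 min (on this read-out higher numbers stand for a more stable compound and lower numbers for a less stable compound), compound 2 `C[C@H](C#Cc1cccc(C(=O)NCCC(c2ccc(F)cc2)c2ccc(OC(F)(F)F)cc2)c1)N(O)C(N)=O` holds the middle place with 43% left. Compound 1 `C[C@H](C#Cc1cccc(C(=O)NCCC(c2ccc(F)cc2)c2ccc(C(F)(F)F)cc2)c1)N(O)C(N)=O` sits higher with 66% left, and compound 3 `CC(C#Cc1cccc(C(=O)NCCC(c2ccccc2)c2ccccc2)c1)N(O)C(N)=O` sits lower with 27% left, both gaps lying beyond the scatter.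

The next compound to be measured is compound 4 `C[C@H](C#Cc1cccc(C(=O)NCCC(c2ccc(F)cc2)c2ccc(F)cc2)c1)N(O)C(N)=O`, and its difference from compound 2 is fluoro in place of trifluoromethoxy on an aromatic carbon. Among the measured compounds shown here, only one measured step involves this place: a number 23 percentage points lower from compound 1 to compound 2 (beyond the scatter) with trifluoromethoxy in place of trifluoromethyl. It shows that a swap here can move the number, but it says nothing directly about fluoro. Compound 3 differs from compound 4 in more than one place, so it is only a loose guide.

With no firm evidence for a direction, the step expected is a number 3 percentage points lower from compound 2 to compound 4 (within the scatter) and no shift beyond the scatter is expected. The estimate for compound 4 is 40% with an expected range of 25% to 58% on this scale.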

Compound 4, percent of the compound remaining in the Rattus norvegicus assay: 50%
Compound 4: the middle estimate sits 10 percentage points below what was measured; measured number inside the range.
By their numbers in the Rattus norvegicus assay, from the lowest: compound 3; then compounds 2 and 4 (each within the scatter of the next); then compound 1.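

At this place, on an aromatic carbon para to a large group, fluoro and trifluoromethoxy cannot be told apart in the Rattus norvegicus assay, with a number 7 percentage points higher from compound 2 to compound 4 (within the scatter). Trifluoromethyl stands apart from fluoro as it does from trifluoromethoxy, with a number 16 percentage points lower from compound 1 to compound 4 (beyond the scatter), so among these three groups only trifluoromethyl gives a number clearly separated from the other two. The change from trifluoromethoxy to fluoro is not silent, however, since it does register in a physicochemical assay for solubility, at pH 7.4; a higher number here means a more soluble compound, a lower number a less soluble compound: the measured solubility of compound 2, 10000 nM, and of compound 4, 3000 nM, a 3.3-fold lower number (0.52 log units; beyond the scatter). In the physicochemical assay compound 2 gives 10000 nM and compound 4 gives 3000 nM.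

The compounds shown leave open how a nitrile or an amine on this same aromatic carbon would fare in the Rattus norvegicus assay and the physicochemical assay. They also leave open whether any group here could match trifluoromethyl in the Rattus norvegicus assay while keeping the higher number that trifluoromethoxy gives in the physicochemical assay.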